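Pyrrole esters of nucleosides: losing the amino group

The compounds below may be only part of what the source reports. "The series", "measured", "known", "first", "only" and "open" are said of these compounds alone.

Two nucleoside esters have been measured in an assay for inhibition of MAP kinase-activated protein kinase 3 (Homo sapiens), read by Z'-LYTE, with a stated time of 1 h, tested at 10 uM; a lower number here means less inhibition, a higher number more inhibition at the concentration tested (going by the name of the read-out). Compound 1 `Nc1ncnc2c1ncn2[C@@H]1O[C@H](COC(=O)c2ccc[nH]2)[C@@H](O)[C@H]1O` gives 98%, and compound 2 `Nc1nc2c(ncn2[C@@H]2O[C@H](COC(=O)c3cc[nH]c3)[C@@H](O)[C@H]2O)c(=O)[nH]1` gives 99%. The two numbers differ by only a sliver, within the scatter of this kind of measurement, so compound 2 and compound 1 sit together near the top of the scale, and no order between them can be claimed.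

Compound 3 `O=C(OC[C@H]1O[C@@H](n2cnc3c(=O)[nH]cnc32)[C@H](O)[C@@H]1O)c1cc[nH]c1` has not yet been measured. It differs from compound 2 in one place: hydrogen in place of amino on an aromatic carbon. Within the data shown here, no other measured pair shows this change, so its effect is unknown. Given that compound 2 already reads 99%, compound 3 is expected to keep strong inhibition, and the estimated step is a number 9 percentage points lower from compound 2 to compound 3 (within the scatter). Compound 3 is therefore estimated at 90%, most likely between 65% and 100%.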

Compound 3, a percentage reported as inhibition, at one concentration (the size of the read-out at that concentration, not a potency): 100%
Compound 3: middle estimate off by 10 percentage points, on the low side; low and high end bracket the measured number.
By their numbers in this assay, from the lowest: compounds 1, 2 and 3 (each within the scatter of the next).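

In this assay, hydrogen in place of amino on an aromatic carbon, between two ring nitrogen atoms, gives a number 1 percentage points higher from compound 2 to compound 3 (within the scatter). The amino group at this position is therefore not needed for the strong inhibition seen at this single concentration, as the reading stays near the top of the scale without it. No available evidence explains this result.

A reading this close to the top of the scale at one concentration cannot show whether compound 2 and compound 3 differ in potency, so a small or even sizeable difference could stay hidden. From the compounds shown here alone, it also remains open how a methyl group, a chlorine atom or a dimethylamino group on the same carbon would read, and whether any of them would lower the inhibition.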